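A fluorophenyl swap on compound 2

A few compounds are considered here, and "the series" means these few. Any claim that something is new, unique, unknown or untested is made for them only; others in the source may bear on it.

Measured in an ADME assay on MRC5 cells (Homo sapiens) for inhibition, with a stated time of 72 h; on this read-out lower numbers stand for an effect already at smaller amounts and higher numbers for an effect only at larger amounts of compound:
Compound 1 `COc1cccc(OC)c1C(=O)Nc1c[nH]nc1C(=O)NC1CC2CCC1C2` gives > 50000 nM as a limit of the assay
Compound 2 `CO[C@H]1CC[C@H](NC(=O)c2n[nH]cc2NC(=O)c2cc(Cl)cc(Cl)c2)CC1` gives 13000 nM as a number
Compound 3 `COc1cccc(OC)c1C(=O)Nc1c[nH]nc1C(=O)NC1CCN(C(=O)OC(C)(C)C)CC1` gives > 50000 nM as a limit of the assay

In this assay, for the measured compounds named here, compound 2 gives the only actual number of the three, and the other two values are limits. Compound 4 `CO[C@H]1CC[C@H](NC(=O)c2n[nH]cc2NC(=O)c2ccccc2F)CC1` has 2-fluorophenyl in place of 3,5-dichlorophenyl on a carbonyl carbon and is otherwise the same as compound 2. Going by the values given here, no measured pair shows the size of such a change. A moderate step towards higher numbers is expected, going from compound 2 at 13000 nM as the sole reference. The expected change is a 3.1-fold higher number from compound 2 to compound 4 (0.49 log units; beyond the scatter) in this estimate. Compound 4 is estimated at 40000 nM within an expected range of 16000 nM to 50000 nM, and a limit of the assay rather than a number is also possible.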

Compound 4, half-maximal effective concentration: 1000 nM
Compound 4: the middle estimate sits 40-fold (1.60 log units) above what was measured; measured number below the stated range.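

In this assay the change to 2-fluorophenyl brings a 13-fold lower number from compound 2 to compound 4 (1.11 log units; beyond the scatter). With the rest of the structure unchanged, the group on this carbonyl carbon can therefore shift the read-out strongly. The earlier compounds could not show this, since only compound 2 had given a number and no step could be read: the limit of > 50000 nM in this assay, at which 2 of the 4 values shown sit.

A single step does not separate the gain of fluorine from the loss of the two chlorines. Going by these compounds, how a plain phenyl or a pyridyl ring at this place would read remains open.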